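The source may report more compounds than this note shows. Statements on the series, on what has been measured and on what is new or still open speak of the compounds shown alone.

Three compounds share one core and differ only in the group on the six-membered aromatic ring of carbon only. Compound 1 `O=[N+]([O-])C1=Cc2cc(C#Cc3ccc(CO)cc3)ccc2OC1C(F)(F)F` gives 2000 nM in an assay on 1321N1 cells for antagonist activity at P2Y purinoceptor 6 (Homo sapiens), read by FLIPR and calcium flux; on this read-out lower numbers stand for stronger inhibition and higher numbers for weaker inhibition. Compound 2 `O=[N+]([O-])C1=Cc2cc(C#Cc3ccc(Cl)cc3)ccc2OC1C(F)(F)F` gives 5350 nM, and compound 3 `O=[N+]([O-])C1=Cc2cc(C#Cc3ccc(O)cc3)ccc2OC1C(F)(F)F` gives 5360 nM, the highest of the three numbers. Compound 3 and compound 2 lie within the scatter of each other, as a 1.0-fold higher number from compound 2 to compound 3 (0.00 log units; within the scatter) shows, whereas a 2.7-fold higher number from compound 1 to compound 3 (0.43 log units; beyond the scatter) lies beyond it. Compound 4 `COC(=O)c1ccc(C#Cc2ccc3c(c2)C=C([N+](=O)[O-])C(C(F)(F)F)O3)cc1` carries methoxycarbonyl in place of hydroxy on an aromatic carbon. Among the measured compounds shown here, no measured step involves methoxycarbonyl; the two steps touching this position, a 2.7-fold higher number from compound 1 to compound 3 (0.43 log units; beyond the scatter) and a 1.0-fold higher number from compound 2 to compound 3 (0.00 log units; within the scatter), were modest or within the scatter, so at most a modest shift, in either direction, is expected. Compound 4 is therefore estimated at 3000 nM, within 1000 nM to 10000 nM. The expected step is a 1.8-fold lower number from compound 3 to compound 4 (0.25 log units; within the scatter).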

Compound 4, half-maximal inhibitory concentration: 3970 nM
The estimate for compound 4 lay 1.3-fold (0.12 log units) below the measured number; low and high end bracket the measured number.
By their numbers in this assay, from the lowest: compounds 1, 4, 2 and 3 (each within the scatter of the next, the first and the last beyond it).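

Methoxycarbonyl, with 4 heavy atoms where hydroxy has 1, stays within the scatter of hydroxy (a 1.4-fold lower number from compound 3 to compound 4 (0.13 log units; within the scatter)), of chloro (a 1.3-fold lower number from compound 2 to compound 4 (0.13 log units; within the scatter)) and of hydroxymethyl (a 2.0-fold higher number from compound 1 to compound 4 (0.30 log units; within the scatter)). This larger group on the aromatic carbon therefore produces no difference that this assay can resolve from any of the three, even though compound 2 and compound 3 lie beyond the scatter of compound 1. Nothing available here explains these small differences. From the compounds shown here alone, whether an amine, a carboxylic acid or a longer chain at this position would move the number beyond the scatter remains open.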